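A few compounds are considered here, and "the series" means these few. Any claim that something is new, unique, unknown or untested is made for them only; others in the source may bear on it.

Working notes. The series pairs an arylsulfonamide with a benzylamine through a diamine linker. Compound 1 `O=S(=O)(NCCCNCc1ccc(Cl)c(Cl)c1)c1cc(C(F)(F)F)cc(C(F)(F)F)c1` gives 2700 nM in a functional assay on MIA PaCa-2 cells (Homo sapiens) for inhibition, read by MTT assay, with a stated time of 72 h; a lower number here means a stronger inhibitor of growth, a higher number a weaker inhibitor of growth. Among the measured compounds shown here, compound 2 `O=S(=O)(NCCCNCc1ccc(Cl)c(C(F)(F)F)c1)c1cc(C(F)(F)F)cc(C(F)(F)F)c1`, which carries trifluoromethyl in place of chloro on the benzyl ring, gives 7400 nM in this assay; the step of a 2.7-fold higher number from compound 1 to compound 2 (0.44 log units; beyond the scatter) is the only single-point change measured so far. Compound 3 `O=S(=O)(NCCCCCCNCc1ccc(Br)cc1)c1ccccc1F` gives 13300 nM in this assay, the highest of the three numbers; its gap to compound 2 lies within the scatter, its gap to compound 1 beyond it.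

Compound 4 `O=S(=O)(NCCCCCCNCc1ccc(Br)cc1)c1ccc(Cl)cc1` differs from compound 3 by 4-chlorophenyl in place of 2-fluorophenyl on a sulfonyl sulfur. For the measured compounds named here, no measured step touches the aryl on the sulfonyl sulfur: the one step on record, a 2.7-fold higher number from compound 1 to compound 2 (0.44 log units; beyond the scatter), concerns the benzyl ring and belongs to a pair whose linker is not that of compound 3, so it gives no direction for this change. The expected step in this assay is therefore a 1.1-fold lower number from compound 3 to compound 4 (0.04 log units; within the scatter), within the scatter. For compound 4 the estimate is 12000 nM, with a range from 4000 nM to 36000 nM.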

Compound 4, concentration for 50% growth inhibition: 5900 nM
Compound 4: middle estimate off by 2.0-fold (0.31 log units), on the high side, within the range that was stated.
By their numbers in this assay, from the lowest: compound 1; then compounds 4, 2 and 3 (each within the scatter of the next, the first and the last beyond it).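

In this assay the aryl on the sulfonyl sulfur turns out to be a position that can shift the number, with 4-chlorophenyl in place of 2-fluorophenyl giving a 2.3-fold lower number from compound 3 to compound 4 (0.35 log units; beyond the scatter), a modest step. Among the compounds shown here, the earlier step concerned only the benzyl ring, so this is the first single-point change on the sulfonyl side of the series, and it lowers the number with the rest of compound 3 unchanged. No measurement shown here accounts for this step.

The change alters both the halogen and its place on the ring, and with neither 4-fluorophenyl nor 2-chlorophenyl among the compounds shown, those two contributions cannot be separated. As far as these compounds go, whether unsubstituted phenyl would sit with compound 3 or compound 4 also remains open, as does the effect of the linker alone.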